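This account rests on a few compounds, and the source may have more. Where it says the series, first, only, none or still open, it means among the compounds named here.

Measured compounds:
Compound 1 `Cc1ccccc1NS(=O)(=O)c1ccc(NC(=O)NCCCCl)cc1` — in a functional assay on MCF7 cells (Homo sapiens) for cytotoxicity, read by sulforhodamine B assay, with a stated time of 48 h (on this read-out lower numbers stand for stronger inhibition and higher numbers for weaker inhibition), compound 1 gives only a limit, > 200000 nM.
Compound 2 `CCc1ccccc1NS(=O)(=O)c1ccc(NC(=O)NCCCCl)cc1` — in this assay compound 2 gives only a limit, > 200000 nM.
Compound 3 `CCNC(=O)Nc1ccc(S(=O)(=O)Nc2ccccc2C)cc1` — in this assay compound 3 gives only a limit, > 200000 nM.

Compound 3 therefore stands at the limit of this assay; (the limit of > 200000 nM in this assay, at which 3 of the 3 values shown sit), so no ordering among the three is readable. Compound 4 `CCNC(=O)Nc1ccc(S(=O)(=O)Nc2ccccc2CC)cc1` differs from compound 3 by methyl in place of hydrogen on a saturated chain carbon bound to an aromatic carbon. The same change is present from compound 1 to compound 2, where the step is a step that the two limits leave unreadable from compound 1 to compound 2, and the step from compound 1 to compound 3, a step that the two limits leave unreadable from compound 1 to compound 3, is likewise unreadable. Within the data shown here, no measured step gives a readable size, so compound 4 is expected to stay at the limit, with the step of a number no higher from compound 3 to compound 4 (the limit leaves the size open). The estimate for compound 4 in this assay is 200000 nM, within 100000 nM to 400000 nM.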

Compound 4, half-maximal inhibitory concentration: 91000 nM
Estimate against measurement, compound 4: 2.2-fold (0.34 log units) above, outside the stated range (below it).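

In this assay, methyl in place of hydrogen on a saturated chain carbon bound to an aromatic carbon now has a readable direction: an at least 2.1-fold lower number from compound 3 to compound 4 (0.34 log units; beyond the scatter). Hydrogen in place of chloromethyl also becomes readable with 2-ethylphenyl in place: an at least 2.1-fold lower number from compound 2 to compound 4 (0.34 log units; beyond the scatter). The steps among the other compounds cannot be read: the limit of > 200000 nM in this assay, at which 3 of the 4 values shown sit.

On these data alone, each readable step starts from a limit, so its full size remains open. Only methyl and ethyl are shown at this place, leaving open how a longer chain such as propyl, or an amine at the chain end, would read.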